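Benzyl in Place of Phenyl on the Amide Nitrogen

The source may report more compounds than this note shows. Statements on the series, on what has been measured and on what is new or still open speak of the compounds shown alone.

Two analogues of a shared core have been measured in an ADME assay on WI-38 cells (Homo sapiens) for cytotoxicity, read by MTT assay, with a stated time of 72 h; on this read-out higher numbers stand for weaker inhibition and lower numbers for stronger inhibition. Compound 1 `CC(C)(C)NC(=O)CCc1cccc2c1B(O)OC2` reaches only the limit of the assay, > 100000 nM. Going by the values given here, compound 2 `O=C(CCc1cccc2c1B(O)OC2)Nc1ccccc1` gives 30000 nM, the only number among the values so far. Compound 3 `O=C(CCc1cccc2c1B(O)OC2)NCc1ccccc1` carries benzyl in place of phenyl on an amide-type nitrogen. Among the compounds with values here, one measured step bears on this change, an at least 3.3-fold lower number from compound 1 to compound 2 (0.52 log units; beyond the scatter), also on the amide-type nitrogen; for the smaller change here no step beyond the scatter is expected, no change at the digits printed from compound 2 to compound 3 (within the scatter). Compound 3 is therefore estimated at 30000 nM, between 10000 nM and 100000 nM.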

Compound 3, half-maximal inhibitory concentration: > 100000 nM
Compound 3: only a limit was reported; the forecaster's own chance of this, stated with the estimate: 30%; middle value at least 3.3-fold (0.52 log units) from the limit.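

Benzyl in place of phenyl on the amide-type nitrogen gives an at least 3.3-fold higher number from compound 2 to compound 3 (0.52 log units; beyond the scatter) in this assay, so even this small change at the position is felt. Of the three groups shown on this nitrogen, only phenyl, in compound 2, gives a number; tert-butyl in compound 1 and benzyl in compound 3 both end at a limit. The step from compound 1 to compound 3 cannot be read, and neither compound can be ranked against the other: the limit of > 100000 nM in this assay, at which 2 of the 3 values shown sit.

On these data alone, it remains open whether an amine or a carboxylic acid on the phenyl of compound 2 would shift the number. A longer chain in place of benzyl also remains untested in the compounds shown here.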